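The compounds below may be only part of what the source reports. "The series", "measured", "known", "first", "only" and "open" are said of these compounds alone.

Measured in an in vitro ADME assay on microsomes from liver (Homo sapiens) for metabolic stability, read by HPLC (on this read-out lower numbers stand for slow clearance and higher numbers for fast clearance), so far:
compound 1 `NC(=O)[C@@H](CCC(F)(F)F)N(CC1COC1)S(=O)(=O)c1ccc(Cl)cc1`: 16.9 mL/min/kg
compound 2 `CC1(C)CO[C@H]1CN([C@H](CCC(F)(F)F)C(N)=O)S(=O)(=O)c1ccc(Cl)cc1`: 262 mL/min/kg
compound 3 `NC(=O)[C@@H](CCC(F)(F)F)N(C[C@H]1CCCCO1)S(=O)(=O)c1ccc(Cl)cc1`: > 300 mL/min/kg, which is a limit of the assay and not a number.

Compound 3 therefore stands at the limit of > 300 mL/min/kg in this assay, at which 1 of the 3 values shown sits, and only a limit is known for it. Among the measured steps, an at least 17-fold higher number from compound 1 to compound 3 (1.24 log units; beyond the scatter) is large, as is a 16-fold higher number from compound 1 to compound 2 (1.19 log units; beyond the scatter); the step of an at least 1.1-fold higher number from compound 2 to compound 3 (0.05 log units; that floor lies within the scatter) has a floor that lies within the scatter.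

Compound 4 `NC(=O)[C@@H](CCC(F)(F)F)N(C[C@@H]1CCCCO1)S(=O)(=O)c1ccc(Cl)cc1` is the next compound for this assay. Against compound 3 the change is the two compounds have the same atoms and bonds and differ only in configuration as drawn: 1 of 2 stereo elements differ; a stereocentre at a saturated ring carbon is drawn R in compound 3 and S in compound 4. Each of the measured steps exchanges the ring itself for a different one; none of them changes configuration alone, so none bears directly on this step, and the data give no measured size for an inversion at a saturated ring carbon. With nothing to set a direction, the expectation for compound 4 is a step of a number no higher from compound 3 to compound 4 (the limit leaves the size open), that is, none beyond the scatter. Compound 4 is accordingly estimated at 300 mL/min/kg, between 100 mL/min/kg and 900 mL/min/kg, with a considerable chance that this assay again returns only a limit.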

Compound 4, clearance: > 300 mL/min/kg
Compound 4 gave a limit, no number; the forecaster's own chance of this, stated with the estimate: 55%; the middle value sits exactly at the limit.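

In this assay compound 4 gives > 300 mL/min/kg, which is a limit of the assay and not a number. The step from compound 3 to compound 4 cannot be read, so the inversion at the saturated ring carbon receives no measured size, and neither drawn configuration of the oxan-2-yl group brings a number off the limit: the limit of > 300 mL/min/kg in this assay, at which 2 of the 4 values shown sit. With the opposite configuration the exchange for oxetan-3-yl still gives an at least 17-fold higher number from compound 1 to compound 4 (1.24 log units; beyond the scatter), so the large step seen earlier with this ring is now seen with both drawn configurations, while the exchange for 3,3-dimethyloxetan-2-yl gives an at least 1.1-fold higher number from compound 2 to compound 4 (0.05 log units; that floor lies within the scatter), and that floor sets no order between the two groups.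

As far as these compounds go, whether the configuration at this ring carbon matters at all stays unknown, since both compounds of the pair end at the same limit of the read-out: the fact that compounds 3 and 4 differ only in the configuration as drawn. Also open, from the compounds shown here alone, is whether a hydroxyl group or an amine on the oxan-2-yl group, or an open ether chain in its place, would return a readable number in this assay and so allow the two configurations to be compared.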